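This account rests on a few compounds, and the source may have more. Where it says the series, first, only, none or still open, it means among the compounds named here.

Measured so far in a functional assay on A549 cells (Homo sapiens) for inhibition, read by MTT assay, with a stated time of 48 h; a higher number here means a weaker inhibitor, a lower number a stronger inhibitor:
compound 1 `CCOC(=O)c1cc(-c2ccccc2)nn1CC(O)COc1ccc([N+](=O)[O-])cc1`: compound 1 gives 48000 nM
compound 2 `CCOC(=O)c1cc(-c2ccc(OC)cc2)nn1CC(O)COc1ccccc1`: compound 2 gives 33000 nM

Compound 2 holds the lower of the two numbers in this assay, but compound 1 sits within the usual scatter of it, so the two values cannot be told apart. Within the data shown here, no step between measured compounds that differ in one place is available, so nothing in the pair says how a single change moves the read-out.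

The next compound, compound 3 `CCOC(=O)c1cc(-c2ccc(OC)cc2)nn1CC(O)COc1ccc([N+](=O)[O-])cc1`, is compound 2 with nitro in place of hydrogen on an aromatic carbon. Compound 1 already carries a nitro group at the same place, with an unsubstituted phenyl on the shared core, and its value lies within the scatter of compound 2. On that basis the step from compound 2 to compound 3 is expected to be small, a 1.1-fold higher number from compound 2 to compound 3 (0.03 log units; within the scatter), with no clear direction beyond the scatter. Compound 3 is therefore estimated at 35000 nM in this assay, with a range from 15000 nM to 80000 nM.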

Compound 3, half-maximal inhibitory concentration: 44000 nM
Estimate against measurement, compound 3: 1.3-fold (0.10 log units) below; the measured number falls inside the stated range.
By their numbers in this assay, from the lowest: compounds 2, 3 and 1 (each within the scatter of the next).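

The change from phenoxy to 4-nitrophenoxy now has a direct reading in this assay: a 1.3-fold higher number from compound 2 to compound 3 (0.12 log units; within the scatter), so this change does not separate the two compounds. Methoxy in place of hydrogen on the phenyl of the shared core, with the nitro group kept, can also be read for the first time: a 1.1-fold lower number from compound 1 to compound 3 (0.04 log units; within the scatter), and this change does not separate them either. No measurement at hand speaks to a cause for these values.

Each reading rests on a single pair, and neither place has yet shown a change beyond the scatter. On these data alone, whether an amine or a carboxylic acid in place of the nitro group, or a longer chain in place of the ethyl of the ester, would move the number remains open.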